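A few compounds are considered here, and "the series" means these few. Any claim that something is new, unique, unknown or untested is made for them only; others in the source may bear on it.

Measured in a functional assay on CWR22R cells (Homo sapiens) for antiproliferative activity, read by CCK-8 assay, with a stated time of 6 days; on this read-out lower numbers stand for stronger inhibition and higher numbers for weaker inhibition:
Compound 1 `CCN(c1ccc(C#N)c(Cl)c1)c1cc(-c2cncnc2)ccc1C`: > 30000 nM, a limit
Compound 2 `CCN(c1ccc(C#N)c(Cl)c1)c1cc(-c2cccs2)ccc1C`: 22000 nM
Compound 3 `CCN(c1ccc(C#N)c(Cl)c1)c1cc(-n2cccn2)ccc1C`: > 30000 nM, a limit

Compound 3 gives only a limit and no number, and it stands at the limit of > 30000 nM in this assay, at which 2 of the 3 values shown sit. Compound 4 `CCN(c1ccc(C#N)c(Cl)c1)c1cc(-c2ccoc2)ccc1C` keeps the shared core and changes one group: furan-3-yl takes the place of 1H-pyrazol-1-yl on an aromatic carbon (furan-3-yl in place of 1H-pyrazol-1-yl on an aromatic carbon).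

Going by the values given here, the steps that bear on this change swap groups at the same place: an at least 1.3-fold lower number from compound 1 to compound 2 (0.13 log units; that floor lies within the scatter), an at least 1.3-fold higher number from compound 2 to compound 3 (0.13 log units; that floor lies within the scatter) and a step that the two limits leave unreadable from compound 1 to compound 3. None of them shows a size beyond the scatter. Only compound 2 gives a number, 22000 nM, and it is the nearest guide. Among the compounds with values here, no large step is therefore expected in this assay, and a reading that stops at the limit remains quite possible. The expected step is small, estimated as an at least 1.2-fold lower number from compound 3 to compound 4 (0.09 log units; that floor lies within the scatter). Compound 4 is estimated at 24000 nM, with an expected range of 12000 nM to 30000 nM.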

Compound 4, half-maximal inhibitory concentration: > 30000 nM
Compound 4: only a limit was reported; the forecaster's own chance of this, stated with the estimate: 45%; at least 1.2-fold (0.09 log units) between middle value and limit.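

In this assay, furan-3-yl in place of thiophen-2-yl gives an at least 1.3-fold higher number from compound 2 to compound 4 (0.13 log units; that floor lies within the scatter), so this swap between two five-membered aromatic rings with one hetero atom shows no clear difference, although the true gap could be larger. Compound 4 gives only a limit, and its steps from compound 1 and compound 3 cannot be read. Compound 1, compound 3 and compound 4 now all stand at the same limit: the limit of > 30000 nM in this assay, at which 3 of the 4 values shown sit.

As far as these compounds go, how compound 1, compound 3 and compound 4 rank among themselves stays open. Also open, from the compounds shown here alone, is whether a group other than an aromatic ring at this place, such as an amine, a carboxylic acid or a longer chain, would give a clearly lower number than compound 2.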